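The compounds below may be only part of what the source reports. "The series", "measured", "known", "first", "only" and "open" are said of these compounds alone.

Measured so far, in an assay on isolated protein for inhibition of ubiquitin carboxyl-terminal hydrolase 7 (Homo sapiens), with stated times of 30 min and 2 h; on this read-out lower numbers stand for stronger inhibition and higher numbers for weaker inhibition:
- compound 1 `Cn1nc2c(=O)n(CC3(O)CCN(Cc4ccc(-c5ccco5)cc4Cl)CC3)cnc2c1-c1ccc(C2(N)CC2)cc1` — 66.1 nM
- compound 2 `Cn1nc2c(=O)n(CC3(O)CCN(Cc4ccc(-c5cnco5)cc4Cl)CC3)cnc2c1-c1ccc(CN)cc1` — 71.6 nM

Compound 1 gives the lower of the two numbers, but compound 2 lies within the scatter of it, so the two read as equivalent on this assay. Compound 3 `Cn1nc2c(=O)n(CC3(O)CCN(Cc4ccc(-c5ccco5)cc4Cl)CC3)cnc2c1-c1ccc(OC(F)F)cc1` is the next member to be measured. It differs from compound 1 by difluoromethoxy in place of 1-aminocyclopropyl on an aromatic carbon; the group that leaves carries 1 hydrogen-bond donor, the group that enters carries none. Going by the values given here, no step between measured compounds is available to calibrate this change. A modest loss of inhibition is expected, as the step of a 2.3-fold higher number from compound 1 to compound 3 (0.36 log units; beyond the scatter), possibly no larger than the scatter. Compound 3 is therefore estimated at 150 nM, within 50 nM to 500 nM.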

Compound 3, half-maximal inhibitory concentration: 179 nM
Compound 3: the middle estimate sits 1.2-fold (0.08 log units) below what was measured, within the range that was stated.
By their numbers in this assay, from the lowest: compounds 1 and 2 (each within the scatter of the next); then compound 3.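

In this assay, going by these compounds alone, 4-(difluoromethoxy)phenyl in place of 4-(1-aminocyclopropyl)phenyl gives a 2.7-fold higher number from compound 1 to compound 3 (0.43 log units; beyond the scatter), the first step that isolates this position. Inhibition weakens beyond the scatter but remains measurable without a hydrogen-bond donor in the group on this aromatic carbon. No supporting data bear on the origin of this step.

The step cannot separate loss of the amine from loss of the three-membered ring or entry of the fluorines. From the compounds shown here alone, how a methoxy group or a carboxylic acid would read at this place in this assay remains open.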